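Nitrile to carboxylic acid on the ether chain

A few compounds are considered here, and "the series" means these few. Any claim that something is new, unique, unknown or untested is made for them only; others in the source may bear on it.

Measured so far in an assay on isolated protein for binding affinity to leukotriene B4 receptor 1 (Homo sapiens), tested at 1 uM; a higher number here means more inhibition at the concentration tested (going by the name of the read-out), a lower number less inhibition:
compound 1 `CCCc1cc(C(C)=O)c(O)cc1OCCCCC#N`, 37%
compound 2 `CC(=O)c1cc(CC(C)O)c(OCCCCC#N)cc1O`, 6%
compound 3 `C=CCc1cc(C(C)=O)c(O)cc1OCCCCC#N`, 57%

Compound 1 stands second highest of the three; compound 3 sits a number 20 percentage points higher from compound 1 to compound 3 (beyond the scatter), compound 2 sits a number 31 percentage points lower from compound 1 to compound 2 (beyond the scatter). Compound 4 `CCCc1cc(C(C)=O)c(O)cc1OCCCCCC(=O)O` differs from compound 1 in one place: carboxymethyl in place of cyano on a saturated chain carbon, four bonds along the chain from an oxygen on an aromatic ring. Among the compounds with values here, no measured step touches the ether chain; the known steps all alter the group on the other side of the shared core, and the largest of them, a number 51 percentage points higher from compound 2 to compound 3 (beyond the scatter), says nothing about the chain terminus. The direction of the change is therefore open, and the expected step, no change at the digits printed from compound 1 to compound 4 (within the scatter), is set near zero with a wide range. Compound 4 is estimated at 37%, between 8% and 72%.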

Compound 4, a percentage reported as inhibition, at one concentration (the size of the read-out at that concentration, not a potency): 24%
Beside the measured number, compound 4's estimate is 13 percentage points above it, and the stated range covers the measured number.
By their numbers in this assay, from the lowest: compound 2; then compound 4; then compound 1; then compound 3.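

In this assay, the ether chain end proves responsive: carboxymethyl in place of cyano, four bonds along the chain from an oxygen on an aromatic ring, gives a number 13 percentage points lower from compound 1 to compound 4 (beyond the scatter). Group size and hydrogen-bond donor count change together in this single step, so it cannot separate the two. No measurement at hand accounts for the drop.

Going by these compounds, a methyl ester or primary amide at the chain end remains open, as does a shorter chain carrying the carboxylic acid. Whether this change would read the same on the core of compound 3 is also unknown.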